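From 4-cyanophenyl to 3-acetylphenyl

The source may report more compounds than this note shows. Statements on the series, on what has been measured and on what is new or still open speak of the compounds shown alone.

Compound 1 `O=C(CCc1cccc2c1B(O)OC2)Nc1ccccc1`: 30000 nM
Compound 2 `N#Cc1ccc(-c2cccc(NC(=O)CCc3cccc4c3B(O)OC4)c2)cc1`: 12000 nM

In an ADME assay on WI-38 cells (Homo sapiens) for cytotoxicity, read by MTT assay, with a stated time of 72 h (a lower number here means a stronger inhibitor, a higher number a weaker inhibitor), compound 2 holds the lower of the two numbers, at 12000 nM. The next compound to be tested is compound 3 `CC(=O)c1cccc(-c2cccc(NC(=O)CCc3cccc4c3B(O)OC4)c2)c1`, and the change that leads to it is 3-acetylphenyl in place of 4-cyanophenyl on an aromatic carbon. Put simply, 3-acetylphenyl sits in place of 4-cyanophenyl on an aromatic carbon. Among the compounds with values here, only one measured step bears on this, and only indirectly: a 2.5-fold lower number from compound 1 to compound 2 (0.40 log units; beyond the scatter). That modest step added a whole 4-cyanophenyl in place of hydrogen. Within the data shown here, the new swap trades one group for another, each with one six-membered aromatic ring of carbon only, and no measured pair shows such a swap. A smaller step is therefore expected in this assay, probably none beyond the scatter, and its direction is open. The expected step is a 1.1-fold higher number from compound 2 to compound 3 (0.03 log units; within the scatter). Compound 3 is estimated at 13000 nM, with an expected range from 6000 nM to 28000 nM.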

Compound 3, half-maximal inhibitory concentration: 2200 nM
Compound 3: middle estimate off by 5.9-fold (0.77 log units), on the high side, outside the stated range (below it).
By their numbers in this assay, from the lowest: compound 3; then compound 2; then compound 1.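

The swap gives a 5.5-fold lower number from compound 2 to compound 3 (0.74 log units; beyond the scatter) in this assay and shows that this position does not treat all aromatic groups alike: 3-acetylphenyl and 4-cyanophenyl each bring one six-membered aromatic ring of carbon only and one hydrogen-bond acceptor, yet their numbers clearly differ. Compared with plain hydrogen, the added group can also matter far more than compound 2 suggested, as 3-acetylphenyl gives a 14-fold lower number from compound 1 to compound 3 (1.13 log units; beyond the scatter) as a large step, where 4-cyanophenyl gave only a modest one. No measurement here explains why these two groups differ.

The swap changes both the group on the added ring and its place on that ring, and these compounds cannot separate the two effects. They also leave open how an amine or a carboxylic acid on that ring would read in this assay and whether the trend would continue.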